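Changing the side chain of compound 2

The source may hold more compounds than are shown below. What is called first, only, known or untested is meant among the compounds shown, and "the series" means these compounds.

In a physicochemical assay for solubility, in phosphate buffer, with a stated time of 18 h, at pH 7.4 (on this read-out lower numbers stand for lower solubility and higher numbers for higher solubility), compound 1 (`COc1cc2ncnc(-n3nc(-c4ccccn4)nc3N)c2cc1[N+](=O)[O-]`) gives 2000 nM and compound 2 (`COCCOc1cc2c(-n3nc(-c4ccccn4)nc3N)ncnc2cc1OC`) gives 8000 nM as the higher of the two numbers. Compound 3 (`CCN(CC)C(=O)COc1cc2c(-n3nc(-c4ccccn4)nc3N)ncnc2cc1OC`) has diethylcarbamoyl in place of methoxymethyl on a saturated chain carbon bound to an oxygen on an aromatic ring. For the measured compounds named here, the only measured step, a 4.0-fold higher number from compound 1 to compound 2 (0.60 log units; beyond the scatter) for 2-methoxyethoxy in place of nitro, was modest and concerns a different change, so it is a loose guide. A small downward step, none beyond the scatter, is expected (a 1.6-fold lower number from compound 2 to compound 3 (0.20 log units; within the scatter)). For compound 3 the estimate, with its range, is 5000 nM (1500 nM to 16000 nM).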

Compound 3, solubility: 42000 nM
Estimate against measurement, compound 3: 8.4-fold (0.92 log units) below; the measured number lies above the stated range.
By their numbers in this assay, from the lowest: compound 1; then compound 2; then compound 3.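

In this assay, the chain itself proves able to move the number: diethylcarbamoyl in place of methoxymethyl, on a saturated chain carbon bound to an oxygen on an aromatic ring, gives a 5.3-fold higher number from compound 2 to compound 3 (0.72 log units; beyond the scatter). Measured against the nitro starting point, (diethylcarbamoyl)methoxy gives a 21-fold higher number from compound 1 to compound 3 (1.32 log units; beyond the scatter), the largest step among these compounds. Nothing measured here explains the rise. On these data alone, it remains open whether the carbonyl or the two ethyl groups carry the step, and how an amine or a carboxylic acid at this chain end would compare.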